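The source may report more compounds than this note shows. Statements on the series, on what has been measured and on what is new or still open speak of the compounds shown alone.

Working notes on the series. Compound 1 `COc1cc(NC(C)CCCNC(=O)Nc2ccc(Br)cc2)c2ncccc2c1` and compound 2 `COc1cc(NC(C)CCCNC(=O)NNC(=O)Nc2ccc(C(F)(F)F)cc2)c2ncccc2c1` share the same core and the same chain; they differ in the arylurea end. In a functional assay on L1210 cells (Mus musculus) for inhibition, read by MTT assay, with a stated time of 72 h (a higher number here means a weaker inhibitor, a lower number a stronger inhibitor), compound 1 gives 18000 nM. In this assay compound 2 gives 18000 nM, level with compound 1 at the digits recorded, within the scatter; the two values show no difference between the two compounds. Compound 3 `COc1cc(NC(C)CCCNC(=O)NNC(=O)Nc2cccc(C(F)(F)F)c2)c2ncccc2c1` is still to be measured in this assay. Compound 3 differs from compound 2 in one place: 3-(trifluoromethyl)phenyl in place of 4-(trifluoromethyl)phenyl on an amide-type nitrogen. Going by the values given here, no pair of measured compounds isolates such a change, so the series itself offers no precedent for the size of this step. On the present numbers the step of no change at the digits printed from compound 2 to compound 3 (within the scatter) is expected to be none beyond the scatter. Compound 3 is accordingly estimated at 18000 nM, with a range from 8000 nM to 40000 nM.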

Compound 3, half-maximal inhibitory concentration: 4000 nM
For compound 3 the middle estimate is 4.5-fold (0.65 log units) above the measured one; measured number outside the range, below it.
By their numbers in this assay, from the lowest: compound 3; then compounds 1 and 2 (each within the scatter of the next).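

In this assay, 3-(trifluoromethyl)phenyl in place of 4-(trifluoromethyl)phenyl on the amide-type nitrogen gives a 4.5-fold lower number from compound 2 to compound 3 (0.65 log units; beyond the scatter). The two groups have the same atoms, joined differently, so this end of the molecule responds to the placement of the trifluoromethyl group alone, which the level values of compounds 1 and 2 gave no sign of. No measurement at hand bears on the reason for this step.

On these data alone, whether the step is tied to trifluoromethyl stays open, since what a 3-chlorophenyl, a 3-methoxyphenyl or an unsubstituted phenyl would do on this nitrogen is unknown. Also open, as far as these compounds go, is whether 3-(trifluoromethyl)phenyl would give a similar step on the shorter urea end of compound 1.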